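A few compounds are considered here, and "the series" means these few. Any claim that something is new, unique, unknown or untested is made for them only; others in the source may bear on it.

Measured in a functional assay on HL-60 cells (Homo sapiens) for cytotoxicity, read by WST assay, with a stated time of 48 h; a higher number here means that more compound is needed for the effect, a lower number that less compound is needed:
- compound 1 `Clc1ccc(C[C@H]2COC[C@@H]2Cc2ccccc2)cc1Cl`: 19000 nM
- compound 2 `Fc1cccc(C[C@H]2COC[C@@H]2Cc2ccc(Cl)c(Cl)c2)c1`: 20000 nM

In this assay, compound 2 gives 20000 nM, level with compound 1 within the scatter. Compound 3 `Cc1ccc(C[C@H]2COC[C@@H]2Cc2ccc(Cl)c(Cl)c2)cc1` follows from compound 2 with one exchange: 4-methylphenyl in place of 3-fluorophenyl on a saturated chain carbon bound to a saturated ring carbon. In words, this is 4-methylphenyl in place of 3-fluorophenyl on a saturated chain carbon bound to a saturated ring carbon.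

Going by the values given here, only one measured step bears on this exchange: a 1.1-fold higher number from compound 1 to compound 2 (0.02 log units; within the scatter), with fluoro in place of hydrogen on an aromatic carbon. Among the compounds with values here, it concerns the ring now being exchanged, but no compound with a methyl group has been measured, so the guidance is partial. No step beyond the scatter is therefore expected in this assay. The estimated change is a 1.1-fold lower number from compound 2 to compound 3 (0.05 log units; within the scatter). For compound 3, the expected value is 18000 nM, with an estimated range of 9000 nM to 35000 nM.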

Compound 3, half-maximal effective concentration: 21000 nM
Compound 3: the middle estimate sits 1.2-fold (0.07 log units) below what was measured; the measured number falls inside the stated range.
By their numbers in this assay, from the lowest: compounds 1, 2 and 3 (each within the scatter of the next).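

In this assay, the first methyl-bearing compound adds a second kind of change at the aromatic ring on the saturated chain carbon bound to a saturated ring carbon: 4-methylphenyl in place of 3-fluorophenyl gives a 1.1-fold higher number from compound 2 to compound 3 (0.02 log units; within the scatter) and adding the methyl group to the unsubstituted ring gives a 1.1-fold higher number from compound 1 to compound 3 (0.04 log units; within the scatter) in this series. Neither step leaves the scatter, so with fluoro and methyl alike, and with either substituent set against the unsubstituted ring, these three compounds show no measurable response to the change made at this ring. No measured evidence bears on why these numbers stay level.

Still open, from the compounds shown here alone, is whether an amine or a carboxylic acid on this ring would shift the number beyond the scatter. Going by these compounds, a longer chain in place of the methyl group remains equally open.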